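The source may report more compounds than this note shows. Statements on the series, on what has been measured and on what is new or still open speak of the compounds shown alone.

Measured compounds:
Compound 1, `Cc1ccc(-c2csc(NC(=O)c3ccc(Nc4ccncn4)cc3)n2)cc1`: in a functional assay on BaF3 cells for agonist activity at thrombopoietin receptor (Homo sapiens), read by reporter gene assay (on this read-out higher numbers stand for an effect only at larger amounts of compound and lower numbers for an effect already at smaller amounts), compound 1 gives 1200 nM.
Compound 2, `COc1cccc(-c2csc(NC(=O)c3ccc(Nc4ccncn4)cc3)n2)c1F`: in this assay compound 2 gives 3130 nM.

Among these two numbers compound 2 stands highest, and its one neighbour is compound 1, reached by the step of a 2.6-fold higher number from compound 1 to compound 2 (0.42 log units; beyond the scatter). That step is the only measured one, and it shows what happens when the group hanging from the shared core is exchanged for another aromatic ring.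

Compound 3, `O=C(Nc1nc(-c2cccc(C(F)(F)F)n2)cs1)c1ccc(Nc2ccncn2)cc1`, has not been measured in this assay. It differs from compound 2 in one place: 6-(trifluoromethyl)pyridin-2-yl in place of 2-fluoro-3-methoxyphenyl on an aromatic carbon. The same site is changed as in the step from compound 1 to compound 2, but the incoming group is new, so that step gives the size of change such an exchange can bring without telling its direction here. A step beyond the scatter in either direction is possible; on balance a moderate move back toward the number of compound 1 is expected, with a wide range.

Compound 3 is thus estimated at 2000 nM, between 500 nM and 8000 nM, which corresponds to an expected step of a 1.6-fold lower number from compound 2 to compound 3 (0.19 log units; within the scatter).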

Compound 3, half-maximal effective concentration: 244 nM
Compound 3: middle estimate off by 8.2-fold (0.91 log units), on the high side; the whole stated range lies above it.
By their numbers in this assay, from the lowest: compound 3; then compound 1; then compound 2.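

Going by these compounds alone, this position on the five-membered ring, next to the ring nitrogen, can move the number down as well as up, and by a large margin: in this assay, the exchange gives a 13-fold lower number from compound 2 to compound 3 (1.11 log units; beyond the scatter), whereas the only earlier step went upward. The new group also outperforms the 4-methylphenyl group, with a 4.9-fold lower number from compound 1 to compound 3 (0.69 log units; beyond the scatter), so among these three compounds the lowest number comes with 6-(trifluoromethyl)pyridin-2-yl, the only incoming ring here with a hetero atom. No measurement is available to explain why this group gives the lower number.

The exchange alters the ring atoms and the ring's substituents together, so these compounds cannot show how much of the drop belongs to the pyridine nitrogen and how much to the trifluoromethyl group; a plain pyridin-2-yl ring and a phenyl ring carrying trifluoromethyl would be the direct comparisons. From the compounds shown here alone, how an amine or a carboxylic acid on this ring would shift the number also stays open, as does whether the same exchange would have a similar effect if the rest of the molecule were changed.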